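The compounds below may be only part of what the source reports. "The series", "measured", "known", "first", "only" and "open" are said of these compounds alone.

Measured in an assay on isolated protein for displacement of a labelled ligand from metabotropic glutamate receptor 5 (Homo sapiens), with a stated time of 60 min, tested at 1 uM; on this read-out higher numbers stand for more inhibition at the one concentration tested (going by the name of the read-out) and lower numbers for less inhibition:
compound 1 `CC1CCN(c2c(S(=O)(=O)c3cc(F)cc(F)c3)cnc3cc(F)ccc23)CC1` gives 77%
compound 2 `CC1CCN(c2c(S(=O)(=O)c3ccc(F)c(F)c3)cnc3cc(F)ccc23)CC1` gives 94%
compound 3 `Cc1cc(C)cc(S(=O)(=O)c2cnc3cc(F)ccc3c2N2CCC(C)CC2)c1` gives 80%

Compound 3 stands second highest of the three: its nearest neighbour is compound 1 (a number 3 percentage points higher from compound 1 to compound 3 (within the scatter), within the scatter), the furthest is compound 2 (a number 14 percentage points lower from compound 2 to compound 3 (beyond the scatter)).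

Compound 4 `COc1cccc(S(=O)(=O)c2cnc3cc(F)ccc3c2N2CCC(C)CC2)c1` differs from compound 3 in one place: 3-methoxyphenyl in place of 3,5-dimethylphenyl on a sulfonyl sulfur. Among the compounds with values here, the steps that bear on this are the other changes of the aryl group on the sulfonyl sulfur, a number 17 percentage points higher from compound 1 to compound 2 (beyond the scatter) and a number 14 percentage points lower from compound 2 to compound 3 (beyond the scatter), both modest, while a number 3 percentage points higher from compound 1 to compound 3 (within the scatter) stayed within the scatter. Within the data shown here, no measured step involves a 3-methoxyphenyl, so no direction can be taken from the data. Compound 4 is therefore expected to stay near compound 3, with a step of a number 2 percentage points lower from compound 3 to compound 4 (within the scatter) in this assay. The estimate for compound 4 is 78%, between 60% and 92%.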

Compound 4, a percentage reported as inhibition, at one concentration (the size of the read-out at that concentration, not a potency): 90%
Compound 4: the middle estimate sits 12 percentage points below what was measured, and the stated range covers the measured number.
By their numbers in this assay, from the lowest: compounds 1, 3, 4 and 2 (each within the scatter of the next, the first and the last beyond it).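

On the sulfonyl sulfur, an oxygen-bearing 3-methoxyphenyl holds up in this assay: a number 10 percentage points higher from compound 3 to compound 4 (within the scatter) and a number 4 percentage points lower from compound 2 to compound 4 (within the scatter) both lie within the scatter, so compound 4 cannot be separated from either. Only a number 13 percentage points higher from compound 1 to compound 4 (beyond the scatter) lies beyond the scatter, which sets compound 4 apart from the 3,5-difluorophenyl compound alone. Nothing on hand explains these steps.

Open, as far as these compounds go, is whether a longer ether such as ethoxy, or an amine or a carboxylic acid on this aryl ring, would be accepted. Readings at one concentration also leave the potency of compound 2 and compound 4 unresolved.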